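Swapping the ring-nitrogen substituent in a pyrazoline series

The source may report more compounds than this note shows. Statements on the series, on what has been measured and on what is new or still open speak of the compounds shown alone.

Measured compounds:
- compound 1, `COc1cc(C2=NNC(c3ccc(Cl)cc3)C2)ccc1O`: 13.9 10^-6 cm/s
- compound 2, `COc1cc(C2=NN(S(=O)(=O)c3ccc(C)cc3)C(c3ccc(Cl)cc3)C2)ccc1O`: 12 10^-6 cm/s

Both compounds were tested in an ADME assay for permeability, using PAMPA, with a stated time of 16 h, tested at 50 ug/mL; a higher number here means that the compound crosses the layer faster, a lower number that the compound crosses the layer more slowly. Compound 2 gives the lower of the two numbers, but the gap to compound 1 is small: a 1.2-fold lower number from compound 1 to compound 2 (0.06 log units; within the scatter). So on the numbers shown, compound 2 and compound 1 cannot be told apart.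

Compound 3, `COc1cc(C2=NN(C(=S)Nc3ccccc3)C(c3ccc(Cl)cc3)C2)ccc1O`, has not yet been measured. It keeps the shared core of compound 2 and changes only the group on the ring nitrogen: a group of 9 heavy atoms (7 carbon, 1 nitrogen, 1 sulfur; one six-membered aromatic ring of carbon only) in place of a group of 10 heavy atoms (7 carbon, 2 oxygen, 1 sulfur; one six-membered aromatic ring of carbon only), on an amine nitrogen in a ring.

For the measured compounds named here, the only measured step that touches this position is the one from compound 1 to compound 2, where a (4-methylphenyl)sulfonyl group replaced a hydrogen on that same ring nitrogen and the number moved by a 1.2-fold lower number from compound 1 to compound 2 (0.06 log units; within the scatter). Going by the values given here, no measured pair shows the group that enters in compound 3, so the change is not covered directly. Given that the one substitution at this position left the number within the scatter, the step of a 1.2-fold lower number from compound 2 to compound 3 (0.08 log units; within the scatter) is expected to be small as well, with no clear direction. Compound 3 is therefore estimated at 10 10^-6 cm/s, in the range 5 10^-6 cm/s to 20 10^-6 cm/s.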

Compound 3, apparent permeability: 9.55 10^-6 cm/s
Estimate against measurement, compound 3: 1.0-fold (0.02 log units) above; the measured number falls inside the stated range.
By their numbers in this assay, from the lowest: compounds 3, 2 and 1 (each within the scatter of the next).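

Compound 3 gives this position a second, quite different group: the entering group has 1 hydrogen-bond donor and 1 hydrogen-bond acceptor, whereas (4-methylphenyl)sulfonyl has 0 hydrogen-bond donors and 2 hydrogen-bond acceptors. Even so, this assay shows a 1.3-fold lower number from compound 2 to compound 3 (0.10 log units; within the scatter), and the comparison with the hydrogen atom of the unsubstituted ring nitrogen shows a 1.5-fold lower number from compound 1 to compound 3 (0.16 log units; within the scatter), so a hydrogen atom and these two larger groups cannot be told apart here, at least across these three compounds. Nothing given here explains why the three numbers stay so close.

As far as these compounds go, it remains open whether an amine on a longer chain or a carboxylic acid on this ring nitrogen would give a step beyond the scatter. From the compounds shown here alone, it is also open whether the same would hold if the 4-chlorophenyl group or the 4-hydroxy-3-methoxyphenyl group, both unchanged across all three compounds, were replaced.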